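The source may report more compounds than this note shows. Statements on the series, on what has been measured and on what is new or still open speak of the compounds shown alone.

Working notes on the series. Two compounds have numbers in an assay on isolated protein for inhibition of Alpha glucosidase (Homo sapiens), with stated times of 5 min and 15 min, tested at 50 uM; a higher number here means more inhibition at the concentration tested (going by the name of the read-out), a lower number less inhibition. Compound 1 `Cc1ccc(/C=C2\CCC/C(=C\c3ccccc3)C2=O)cc1` gives 34.1% in this assay. Compound 2 `O=C(C1=C(O)/C(=C/c2ccc(O)c(O)c2)CCC1)c1ccccc1` gives 55.9% in this assay. On these two numbers compound 1 stands lowest, with compound 2 the nearest neighbour at a value higher by more than the usual scatter of repeats. Among the compounds with values here, no step between compounds that differ in a single place is known, so the two numbers say only that compound 2 inhibits more at the tested concentration than compound 1 does.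

The next compound, compound 3 `O=C1/C(=C/c2ccccc2)CCC/C1=C\c1cccc(Br)c1`, has not been measured in this assay. Relative to compound 1 the change is 3-bromophenyl in place of 4-methylphenyl on a double-bonded chain carbon bound to a double-bonded ring carbon. The shared core is kept. Within the data shown here, with no measured single-change step to lean on, only a small step is expected in this assay, of uncertain direction, and nothing beyond the scatter is anticipated. Compound 3 is estimated to give 38% in this assay, within a range from 22% to 55%. The expected step from compound 1 to compound 3 is therefore a number 3.9 percentage points higher from compound 1 to compound 3 (within the scatter).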

Compound 3, a percentage reported as inhibition, at one concentration (the size of the read-out at that concentration, not a potency): 27.2%
Compound 3: middle estimate off by 10.8 percentage points, on the high side, within the range that was stated.
By their numbers in this assay, from the lowest: compounds 3 and 1 (each within the scatter of the next); then compound 2.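

In this assay, within the data shown here, 3-bromophenyl in place of 4-methylphenyl on a double-bonded chain carbon bound to a double-bonded ring carbon gives a number 6.9 percentage points lower from compound 1 to compound 3 (within the scatter), the first step that differs in one place only. At this position, then, the exchange of one phenyl group carrying a single substituent for another, with the heavy-atom count of the group unchanged and the shared core kept, leaves the read-out within what repeats would scatter by, so neither the kind of substituent nor its place on the ring separates these two compounds here. Nothing available bears on why the step is this size.

This single step changes the substituent and its place on the phenyl ring together, so it leaves open what either change does alone, for example with the bromine kept and moved to the 4-position. Also open, on these data alone, is whether a group of a different kind on this phenyl ring, such as an amine or a carboxylic acid, would produce a step beyond the scatter.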